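The compounds below may be only part of what the source reports. "The series", "measured", "known", "first", "only" and "open" are said of these compounds alone.

In an in vitro functional assay on cells for agonist activity at Bombesin receptor subtype-3 (Mus musculus), read by luminescence and calcium flux (on this read-out lower numbers stand for an effect already at smaller amounts and higher numbers for an effect only at larger amounts of compound), compound 2 `CC(C)CCc1cnc(CCc2ccc(-c3ccccc3C(=O)O)cc2)[nH]1` gives 10 nM. Within the data shown here, the only other number known here belongs to compound 1 `O=C(O)c1ccccc1-c1ccc(CCc2ncc(Cc3ccccc3F)[nH]2)cc1`, which gives 9.5 nM in this assay, and the step of a 1.1-fold higher number from compound 1 to compound 2 (0.02 log units; within the scatter) shows that these two compounds stand within the scatter of each other. Compound 3 `CCC(C)(CC)Cc1cnc(CCc2ccc(-c3ccccc3C(=O)O)cc2)[nH]1` differs from compound 2 by 1-ethyl-1-methylpropyl in place of isobutyl on a saturated chain carbon bound to an aromatic carbon. The step from compound 1 to compound 2 is the only measured one bearing on this change, and it was small. A step of a 1.2-fold higher number from compound 2 to compound 3 (0.08 log units; within the scatter) is therefore expected, because a 1.1-fold higher number from compound 1 to compound 2 (0.02 log units; within the scatter) already shows little movement at this position. For compound 3 the estimate is 12 nM, from 4 nM to 40 nM.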

Compound 3, half-maximal effective concentration: 30 nM
Estimate against measurement, compound 3: 2.5-fold (0.40 log units) below, and the stated range covers the measured number.
By their numbers in this assay, from the lowest: compounds 1 and 2 (each within the scatter of the next); then compound 3.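

This position is not indifferent to every group. In this assay, 1-ethyl-1-methylpropyl gives a 3.0-fold higher number from compound 2 to compound 3 (0.48 log units; beyond the scatter) and a 3.2-fold higher number from compound 1 to compound 3 (0.50 log units; beyond the scatter), so this change moves the number modestly beyond the scatter, while isobutyl and 2-fluorophenyl had stood within the scatter of each other. No measurement here explains this shift.

On these data alone, whether a straight hexyl chain, an amine or a hydroxyl group in this place would shift the number stays open. So does whether the branching or the added carbons account for the step.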